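A Chloro-to-Bromo Swap on a Shared Core

This account rests on a few compounds, and the source may have more. Where it says the series, first, only, none or still open, it means among the compounds named here.

Of the compounds shown here, three built on a shared core have been measured in a functional assay on KYSE-450 cells (Homo sapiens) for inhibition, read by MTT assay, with a stated time of 48 h; on this read-out lower numbers stand for stronger inhibition and higher numbers for weaker inhibition. Compound 1 `C/C=C/C(=O)N(Cc1cccc(O)c1)c1cc(OC)c(OC)c(OC)c1` gives 14700 nM in this assay. Compound 2 `COc1ccc(CN(C(=O)CCl)c2cc(OC)c(OC)c(OC)c2)cc1O` gives 210 nM in this assay. Compound 3 `COc1ccc(CNc2cc(OC)c(OC)c(OC)c2)cc1Br` gives 39800 nM in this assay. Compound 2 therefore stands lowest of the three numbers; its nearest neighbour, compound 1, sits beyond the usual scatter above it, and compound 3 sits further still, also beyond the scatter. No two of these measured compounds differ in one place only, so none of the gaps between them can be read as a single structural step.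

Compound 4 `COc1ccc(CN(C(=O)CBr)c2cc(OC)c(OC)c(OC)c2)cc1O` has not yet been measured in this assay. It differs from compound 2 in one place: bromo in place of chloro on a saturated chain carbon bound to a carbonyl carbon The same difference, cut one bond further out, reads chloromethyl to bromomethyl, or (chloromethyl)carbonyl to (bromomethyl)carbonyl. Going by the values given here, nothing among the measured compounds shows what such an exchange does on this core. Compound 4 is expected to give 160 nM in this assay, with a range from 50 nM to 600 nM. That estimate means an expected step from compound 2 to compound 4 of a 1.3-fold lower number from compound 2 to compound 4 (0.12 log units; within the scatter), which is not expected to reach beyond the usual scatter in either direction.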

Compound 4, half-maximal inhibitory concentration: 120 nM
Compound 4: middle estimate off by 1.3-fold (0.12 log units), on the high side, and the stated range covers the measured number.
By their numbers in this assay, from the lowest: compounds 4 and 2 (each within the scatter of the next); then compound 1; then compound 3.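

In this assay, going by these compounds alone, the comparison of compound 2 and compound 4 supplies the only single-place step on this core, and it reads a 1.8-fold lower number from compound 2 to compound 4 (0.24 log units; within the scatter) within the printed scatter, for bromo in place of chloro on a saturated chain carbon bound to a carbonyl carbon. Within the data shown here, this shows that, on this core and at this place, the number does not depend on which of these two halogens is carried: compound 2 and compound 4 cannot be told apart in this read-out, something the earlier compounds, none of which differed in one place only, could not show. No other measurement at hand bears on why the two numbers lie so close together.

What the compounds shown leave open is whether the same place would accept other groups, such as an iodo or a fluoro, or a plain hydrogen that would turn the chloromethyl into a simple methyl, and so whether a halogen is needed there at all. They also leave open whether the match between chloro and bromo would hold in other cell lines or at other exposure times.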